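The compounds below may be only part of what the source reports. "The series", "measured", "known", "first", "only" and "open" are said of these compounds alone.

Compound 1 `O=C(OCc1ccccc1)N1CCN(C(=S)SCc2cn(Cc3ccc(Cl)cc3)nn2)CC1`: only a limit, > 128000 nM
Compound 2 `S=C(SCc1cn(Cc2ccccc2Cl)nn1)N1CCNCC1`: only a limit, > 128000 nM
Compound 3 `COc1cc(Cn2cc(CSC(=S)N3CCN(C(=O)OCc4ccccc4)CC3)nn2)cc(OC)c1OC`: only a limit, > 128000 nM

In a functional assay on ECa-109 cells (Homo sapiens) for inhibition, read by MTT assay, with a stated time of 72 h (on this read-out lower numbers stand for stronger inhibition and higher numbers for weaker inhibition), compound 3 gives no number, only the limit > 128000 nM. Compound 1 and compound 2 sit at that same limit, so compound 3 stands nowhere in particular among them: all three values are the limit (the limit of > 128000 nM in this assay, at which 3 of the 3 values shown sit). Going by the values given here, the one measured step, a step that the two limits leave unreadable from compound 1 to compound 3, cannot be read in size or direction, because both of its ends rest on (the limit of > 128000 nM in this assay, at which 3 of the 3 values shown sit).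

Compound 4 `O=C(OCc1ccccc1)N1CCN(C(=S)SCc2cn(Cc3ccccc3Cl)nn2)CC1` differs from compound 3 by 2-chlorophenyl in place of 3,4,5-trimethoxyphenyl on a saturated chain carbon bound to an aromatic nitrogen. Among the compounds with values here, no measured step bears on this change in a readable way, since the only step between the measured compounds is hidden by the limit. With every measured value at the limit, the expectation for compound 4 in this assay is again no number beyond it. Compound 4 is therefore estimated at 200000 nM, within 60000 nM to 1000000 nM. The step from compound 3 to compound 4 is expected to be a step that the limit leaves unreadable from compound 3 to compound 4, which is nothing beyond the scatter.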

Compound 4, half-maximal inhibitory concentration: 56800 nM
Compound 4: middle estimate off by 3.5-fold (0.55 log units), on the high side; measured number below the stated range.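

In this assay, going by these compounds alone, 2-chlorophenyl in place of 3,4,5-trimethoxyphenyl on a saturated chain carbon bound to an aromatic nitrogen gives an at least 2.2-fold lower number from compound 3 to compound 4 (0.35 log units; beyond the scatter), the first readable change at this place. The place also separates the two chlorophenyl groups, as 2-chlorophenyl in place of 4-chlorophenyl gives an at least 2.2-fold lower number from compound 1 to compound 4 (0.35 log units; beyond the scatter). With 2-chlorophenyl held fixed, benzyloxycarbonyl in place of hydrogen on an amine nitrogen in a ring gives an at least 2.2-fold lower number from compound 2 to compound 4 (0.35 log units; beyond the scatter), and each of these three steps is only a bound, as its other end rests on a limit: the limit of > 128000 nM in this assay, at which 3 of the 4 values shown sit.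

Going by these compounds, the true size of these steps stays open, and the step between the remaining limit compounds cannot be read. Also open, on these data alone, is whether the lower number holds with another group at this place, such as an unsubstituted phenyl or a 2-fluorophenyl.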